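Swapping a Ring Oxygen for Carbon on a Second Core

A few compounds are considered here, and "the series" means these few. Any claim that something is new, unique, unknown or untested is made for them only; others in the source may bear on it.

In an ADME assay for permeability, using PAMPA, with a stated time of 4 h (on this read-out lower numbers stand for lower permeability and higher numbers for higher permeability), compound 1 `Cn1c(COc2cccc(C(=O)O)c2)nc2ccc(Oc3ccc4c(c3)CCC4)nc21` gives 31.5 10^-6 cm/s, while compound 2 `Cn1c(COc2cccc(C(=O)O)c2)nc2ccc(Oc3ccc4c(c3)OCC4)nc21` gives 9.1 10^-6 cm/s. Going from compound 2 to compound 1 involves a single change, (a group of 9 heavy atoms (9 carbon; one five-membered non-aromatic ring of carbon only, one six-membered aromatic ring of carbon only) in place of a group of 9 heavy atoms (8 carbon, 1 oxygen; one five-membered non-aromatic ring with 1 hetero atom, one six-membered aromatic ring of carbon only), on an oxygen on an aromatic ring), and the outcome of that change is a 3.5-fold higher number from compound 2 to compound 1 (0.54 log units; beyond the scatter). Compound 3 `Cn1c(COc2cccc(C(=O)O)c2)nc2cnc(Oc3ccc4c(c3)OCC4)cc21` is built from the same atoms as compound 2, joined differently; how the two cores differ is not broken down here. In this assay compound 3 gives 3.6 10^-6 cm/s. Compound 4 `Cn1c(COc2cccc(C(=O)O)c2)nc2cnc(Oc3ccc4c(c3)CCC4)cc21` carries the same change, now made on the core of compound 3: a group of 9 heavy atoms (9 carbon; one five-membered non-aromatic ring of carbon only, one six-membered aromatic ring of carbon only) in place of a group of 9 heavy atoms (8 carbon, 1 oxygen; one five-membered non-aromatic ring with 1 hetero atom, one six-membered aromatic ring of carbon only), on an oxygen on an aromatic ring. Since the change sits at the same place in both pairs, a comparable step is expected, and the estimated 3.3-fold higher number from compound 3 to compound 4 (0.52 log units; beyond the scatter) rests on a 3.5-fold higher number from compound 2 to compound 1 (0.54 log units; beyond the scatter), a single earlier example. Compound 4 is therefore expected to give roughly 12 10^-6 cm/s in this assay, most likely between 6 10^-6 cm/s and 24 10^-6 cm/s.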

Compound 4, apparent permeability in the ADME assay: 16.5 10^-6 cm/s
Estimate against measurement, compound 4: 1.4-fold (0.14 log units) below; measured number inside the range.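

In the ADME assay compound 3 gives 3.6 10^-6 cm/s and compound 4 gives 16.5 10^-6 cm/s with 2,3-dihydro-1H-inden-5-yl in place of the group with the ring oxygen, which gives a 4.6-fold higher number from compound 3 to compound 4 (0.66 log units; beyond the scatter), and this step agrees with the earlier one on the other core: the same change on two cores in the ADME assay, a 3.5-fold higher number (0.54 log units; beyond the scatter) from compound 2 to compound 1 and a 4.6-fold higher number (0.66 log units; beyond the scatter) from compound 3 to compound 4, 1.3-fold (0.12 log units) apart, within the scatter of two such steps. In these two pairs, then, the change carries from one core to the other at much the same size, but two pairs make no general rule and do not show why the step arises. In a physicochemical assay for solubility, read by HPLC, measured as thermodynamic solubility, with a stated time of 4 h, at pH 6.8 (on this read-out lower numbers stand for lower solubility and higher numbers for higher solubility), compound 3 gives 79 ug/mL and compound 4 gives 70 ug/mL and the same change gives a 1.1-fold lower number from compound 3 to compound 4 (0.05 log units; within the scatter), a step within the scatter, so this read-out does not separate the two compounds on this core.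

From the compounds shown here alone, it remains open whether the step would hold on a third core. Also open, going by these compounds, is how an amine nitrogen in place of the ring oxygen would compare.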